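This account rests on a few compounds, and the source may have more. Where it says the series, first, only, none or still open, it means among the compounds named here.

Compound 1 `C[C@H](Oc1ccc(S(C)(=O)=O)cc1C(=O)N1Cc2cc(C(F)(F)F)cnc2C1)C(F)(F)F` in an in vitro ADME assay on microsomes from liver (Rattus norvegicus) for metabolic stability (a lower number here means slower removal, a higher number faster removal of the compound), gives 1.9 mL.min-1.g-1
Compound 2 `C[C@H](Oc1ccc(S(C)(=O)=O)cc1C(=O)N1Cc2ccc(C3CCOCC3)cc2C1)C(F)(F)F` in this assay gives 13.9 mL.min-1.g-1

Of these two compounds, compound 2 has the higher number, so it is removed faster, and its gap to compound 1 lies beyond the usual scatter of repeat measurements. The two differ in more than one place, so that gap cannot be tied to any single group.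

Compound 3 `CC(C)Oc1ccc(S(C)(=O)=O)cc1C(=O)N1Cc2ccc(C3CCOCC3)cc2C1` keeps the rest of compound 2 but has isopropyl in place of 1-(trifluoromethyl)ethyl on an oxygen on an aromatic ring. Going by the values given here, no measured pair shows this change alone, so the direction is a judgement and not a reading from the data. A modest rise in this assay is expected, as a 1.6-fold higher number from compound 2 to compound 3 (0.20 log units; within the scatter) in this estimate, and it may stay within the scatter. In this assay compound 3 is estimated at 22 mL.min-1.g-1 with a range of 11 mL.min-1.g-1 to 45 mL.min-1.g-1 expected for the measurement.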

Compound 3, intrinsic clearance in microsomes: 18.9 mL.min-1.g-1
The estimate for compound 3 lay 1.2-fold (0.07 log units) above the measured number; the range from low to high includes it.
By their numbers in this assay, from the lowest: compound 1; then compounds 2 and 3 (each within the scatter of the next).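

Exchanging 1-(trifluoromethyl)ethyl for isopropyl on an oxygen on an aromatic ring gives, in this assay, a 1.4-fold higher number from compound 2 to compound 3 (0.13 log units; within the scatter), so this pair cannot be told apart by this measurement. Going by these compounds alone, this is the first single-place comparison at this position: on the core of compound 2, the exchange removes 3 fluorine atoms and the defined stereocentre without a step beyond the scatter. No supporting measurement explains why the step is this small.

From the compounds shown here alone, whether a shorter group such as methyl, or a ring such as cyclopropyl, on this oxygen would stay within the scatter of compound 2 remains open. Going by these compounds, it is also open whether the same exchange on the core of compound 1 would give a similarly small step, and the gap between compound 1 and compound 2 still cannot be tied to any single group.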